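Cyano on the benzamide phenyl: toxicity series notes

This account rests on a few compounds, and the source may have more. Where it says the series, first, only, none or still open, it means among the compounds named here.

Measured compounds, toxicity read-out in a toxicity assay on THP-1 cells (Homo sapiens) for inhibition; on this read-out lower numbers stand for higher toxicity in this test and higher numbers for lower toxicity in this test:
- compound 1 `COc1ccc(-c2cnc(NC(=O)c3cccnc3)n2C)cc1`, which gives > 100000 nM, a limit of the assay
- compound 2 `CCC(=O)Nc1ncc(-c2ccc(OC)cc2)n1C`, which gives > 100000 nM, a limit of the assay
- compound 3 `COc1ccc(-c2cnc(NC(=O)c3ccccc3)n2C)cc1`, which gives > 100000 nM, a limit of the assay

Compound 3 stands at the limit of this assay, and the two other compounds stand at the same limit. The steps among them, a step that the two limits leave unreadable from compound 1 to compound 2, a step that the two limits leave unreadable from compound 1 to compound 3 and a step that the two limits leave unreadable from compound 2 to compound 3, are therefore not readable in size; all that is known is the limit of > 100000 nM in this assay, at which 3 of the 3 values shown sit.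

Compound 4 `COc1ccc(-c2cnc(NC(=O)c3ccc(C#N)cc3)n2C)cc1` differs from compound 3 by cyano in place of hydrogen on an aromatic carbon. Within the data shown here, no measured step concerns this change; the three steps that are known only show that the amide substituent, from ethyl to pyridin-3-yl to phenyl, has not moved any compound off the limit. Compound 4 is therefore expected to stay at the limit as well, with the expected step of a number no higher from compound 3 to compound 4 (the limit leaves the size open). The estimate for compound 4 in this assay is 100000 nM, with a range from 40000 nM to 300000 nM.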

Compound 4, half-maximal cytotoxic concentration: > 100000 nM
Compound 4 was reported as a limit; the forecaster's own chance of this, stated with the estimate: 85%; the middle value lies on the limit itself.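

Compound 4 sits at the same limit as compound 1, compound 2 and compound 3 in this assay, so none of the steps to compound 4 can be read: the limit of > 100000 nM in this assay, at which 4 of the 4 values shown sit.

The compounds shown leave open whether any change to the amide substituent or the shared core gives a readable value in this assay.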